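The compounds below may be only part of what the source reports. "The series", "measured", "known", "first", "only" and "open" are said of these compounds alone.

In a functional assay on LOX IMVI cells (Homo sapiens) for antiproliferative activity (on this read-out higher numbers stand for weaker inhibition of growth and lower numbers for stronger inhibition of growth), compound 1 `COc1cc(-n2cc(-c3ccc(Cl)cc3)[nH]c2=O)cc(OC)c1OC` gives 63100 nM. Within the data shown here, the only other measured compound, compound 2 `O=c1[nH]c(-c2ccc(Cl)c(Cl)c2)cn1-c1ccc(Cl)cc1`, gives 39800 nM. These two numbers lie within the usual scatter of each other, so neither compound can be ranked above the other. The next compound to test is compound 3 `COc1cc(-n2cc(-c3ccccc3)[nH]c2=O)cc(OC)c1OC`, which differs from compound 1 in one place: hydrogen in place of chloro on an aromatic carbon. Hydrogen stands in place of chloro on an aromatic carbon, turning the 4-chlorophenyl into phenyl. Among the measured compounds shown here, compounds 1 and 2 differ in more than one place, so no measured pair shows what this single change does. With no such evidence, no step beyond the scatter is expected in this assay, and no direction can be favoured. The expected change is a 1.3-fold lower number from compound 1 to compound 3 (0.10 log units; within the scatter), which is within the scatter. For compound 3, the estimated value is 50000 nM, with an expected range of 20000 nM to 100000 nM.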

Compound 3, concentration for 50% growth inhibition: > 100000 nM
Compound 3: a limit, no number (the forecaster's own chance of this, stated with the estimate: 20%); middle value at least 2.0-fold (0.30 log units) from the limit.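

Among these compounds, the change from the 4-chlorophenyl to phenyl gives the first direct reading at this position: in this assay there is an at least 1.5-fold higher number from compound 1 to compound 3 (0.19 log units; that floor lies within the scatter). Only a floor is known for this step, and because that floor lies within the scatter, the result fits a small step as well as a large one. The full size of the step cannot be read, because the value of compound 3 is a limit of the assay and not a number: the limit of > 100000 nM in this assay, at which 1 of the 3 values shown sits.

The compounds shown leave open what a fluoro, a bromo or an amine in this place on the ring would do, and whether any of these would bring the number below that of compound 1. They also leave open whether removing a chloro from the core of compound 2 would give a similar step.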